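This account rests on a few compounds, and the source may have more. Where it says the series, first, only, none or still open, it means among the compounds named here.

Values in a functional assay on PC-3 cells (Homo sapiens) for cytotoxicity, read by sulforhodamine B assay, with a stated time of 48 h (a lower number here means a stronger inhibitor, a higher number a weaker inhibitor), for the compounds measured so far:

Compound 1 `C[C@H]1CC[C@@H]2[C@@H](OC(=O)[C@]23CC(c2ccccc2)=NO3)[C@]2(C)C(=O)C=C[C@@]12O` gives 46000 nM
Compound 2 `C[C@H]1CC[C@@H]2[C@@H](OC(=O)[C@]23CC(c2ccccc2[N+](=O)[O-])=NO3)[C@]2(C)C(=O)C=C[C@@]12O` gives 37000 nM
Compound 3 `COc1cc(C2=NO[C@]3(C2)C(=O)O[C@@H]2[C@H]3CC[C@H](C)[C@]3(O)C=CC(=O)[C@@]23C)ccc1O` gives 16000 nM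

Compound 3 has the lowest number of the three in this assay and stands clear of both others, though not by much. The record shows a 2.3-fold lower number from compound 2 to compound 3 (0.36 log units; beyond the scatter) and a 2.9-fold lower number from compound 1 to compound 3 (0.46 log units; beyond the scatter) as its two modest steps.

The next compound to be tested is compound 4 `C[C@H]1CC[C@@H]2[C@@H](OC(=O)[C@]23CC(c2cccc([N+](=O)[O-])c2)=NO3)[C@]2(C)C(=O)C=C[C@@]12O`, which carries 3-nitrophenyl in place of 4-hydroxy-3-methoxyphenyl on a carbon with a double bond to nitrogen. The change is 3-nitrophenyl in place of 4-hydroxy-3-methoxyphenyl on a carbon with a double bond to nitrogen and it removes the group that only compound 3 carries. The two steps into compound 3 bear on this most directly, since they install that same group on the same carbon, so the change to compound 4 runs against them. Adding a nitro group to the phenyl ring gave a 1.2-fold lower number from compound 1 to compound 2 (0.09 log units; within the scatter) but at a different ring position, and the 3-nitrophenyl group itself has not been measured. Compound 4 is therefore expected to return to the level of compound 1 and compound 2. The expected change is a 2.4-fold higher number from compound 3 to compound 4 (0.38 log units; beyond the scatter) and so a modest rise. Compound 4 is estimated at 38000 nM with an expected range of 17000 nM to 85000 nM in this measurement.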

Compound 4, half-maximal inhibitory concentration: 55000 nM
Beside the measured number, compound 4's estimate is 1.4-fold (0.16 log units) below it; the measured number falls inside the stated range.
By their numbers in this assay, from the lowest: compound 3; then compounds 2, 1 and 4 (each within the scatter of the next).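

In this assay, the new 3-nitrophenyl group cannot be told apart from the unsubstituted phenyl (a 1.2-fold higher number from compound 1 to compound 4 (0.08 log units; within the scatter)) or from the 2-nitrophenyl group (a 1.5-fold higher number from compound 2 to compound 4 (0.17 log units; within the scatter)), so among the compounds shown, a nitro group at either of these two ring positions leaves the number at the level of the plain phenyl compound. Removing the 4-hydroxy-3-methoxyphenyl group gives a 3.4-fold higher number from compound 3 to compound 4 (0.54 log units; beyond the scatter), which means that compound 3 now stands apart, beyond the scatter, from three compounds that differ from it only in the group on this carbon, and that it alone has the lowest number in the set. Nothing measured here offers an explanation for why this one group separates from the others.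

The compounds shown leave open whether the hydroxy group, the methoxy group or the two together account for the lower number of compound 3, since they enter as one group in every comparison. They also leave open how a 4-nitrophenyl group, or an amine or a carboxylic acid on the same ring, would compare at this position.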